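The source may report more compounds than this note shows. Statements on the series, on what has been measured and on what is new or still open speak of the compounds shown alone.

In an ADME assay on microsomes from liver (Rattus norvegicus) for metabolic stability, read by LC-MS, using NADPH, with a stated time of 45 min, tested at 2 uM (on this read-out lower numbers stand for a less stable compound and higher numbers for a more stable compound), compound 1 `Cc1ccc(C(N)=O)cc1-n1c(C)cc(OCc2ccc(F)cc2F)c(Br)c1=O` gives 100%, the higher of the two numbers available, while compound 2 `Cc1ccc(C(=O)N(C)C)cc1-n1c(C)cc(OCc2ccc(F)cc2F)c(Br)c1=O` gives 71%. Compound 3 `Cc1cc(OCc2ccc(F)cc2F)c(Br)c(=O)n1-c1cccc(C(N)=O)c1` keeps the carbamoyl group of compound 1. Its change is hydrogen in place of methyl on an aromatic carbon, ortho to a large group and para to a carbamoyl group: hydrogen in place of methyl on an aromatic carbon. Within the data shown here, the only measured step, a number 29 percentage points lower from compound 1 to compound 2 (beyond the scatter), is dimethylamino in place of amino on a carbonyl carbon. It does not touch this methyl, so it bears only indirectly, showing that a single change can move this assay beyond the scatter. With compound 1 at 100%, little room remains for a rise. A modest fall is therefore expected, and the estimated step is a number 15 percentage points lower from compound 1 to compound 3 (beyond the scatter). The expected value for compound 3 is 85%, with an estimated range from 60% to 100%.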

Compound 3, percent of the compound remaining: 97%
For compound 3 the middle estimate is 12 percentage points below the measured one, and the stated range covers the measured number.
By their numbers in this assay, from the lowest: compound 2; then compounds 3 and 1 (each within the scatter of the next).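

In this assay, the methyl on the aromatic carbon, ortho to a large group and para to a carbamoyl group, can be replaced by hydrogen with a number 3 percentage points lower from compound 1 to compound 3 (within the scatter), so for this pair the methyl makes no difference that can be told from the scatter. The earlier step, a number 29 percentage points lower from compound 1 to compound 2 (beyond the scatter), had shown that a change on the carbonyl carbon moves this read-out beyond the scatter; this change, made elsewhere on the same aromatic ring, does not. Nothing available bears on why this read-out stays put when the methyl leaves.

The compounds shown leave open how a larger group at this place, such as ethyl or methoxy, would read. They also leave open whether hydrogen in place of methyl would behave the same way alongside the dimethylamino group of compound 2.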